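The source may hold more compounds than are shown below. What is called first, only, known or untested is meant among the compounds shown, and "the series" means these compounds.

The measured compounds:
compound 1 `O=C(O)/C(S)=C/c1c[nH]c2cc(Br)ccc12`: 90 nM
compound 2 `O=C(O)/C(S)=C/c1cccc(F)c1`: 31500 nM
compound 3 `O=C(O)/C(S)=C/c1c[nH]c2c(F)cccc12`: 110 nM

In an assay on isolated protein for inhibition of Calpain-1 catalytic subunit (Sus scrofa) (on this read-out higher numbers stand for weaker inhibition and lower numbers for stronger inhibition), compound 1 gives 90 nM, the lowest of the three numbers. Compound 3 gives 110 nM, a number that sits within the scatter of compound 1, so the two cannot be told apart on this read-out. Compound 2 gives 31500 nM, a number far beyond the scatter from compound 1 and from compound 3.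

Compound 4 `O=C(O)/C(S)=C/c1c[nH]c2cc(F)ccc12` has not yet been measured. It differs from compound 1 in one place: fluoro in place of bromo on an aromatic carbon. Among the measured compounds shown here, no pair of measured compounds shows this exchange, so its size is not known from the data. Compound 3, which carries a fluoro elsewhere on the shared core and gives 110 nM, shows that a core of this kind bearing a fluoro can reach the level of compound 1. On that basis the step in this assay is expected to be a 1.7-fold higher number from compound 1 to compound 4 (0.22 log units; within the scatter), a small shift toward weaker inhibition that is not expected to go beyond the scatter. Compound 4 is therefore expected to give 150 nM, with a range from 60 nM to 400 nM.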

Compound 4, half-maximal inhibitory concentration: 300 nM
For compound 4 the middle estimate is 2.0-fold (0.30 log units) below the measured one; low and high end bracket the measured number.
By their numbers in this assay, from the lowest: compounds 1 and 3 (each within the scatter of the next); then compound 4; then compound 2.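

The exchange of bromo for fluoro now has a measured size: on the aromatic carbon that stands meta to a fused ring and para to a fused ring, it gives a 3.3-fold higher number from compound 1 to compound 4 (0.52 log units; beyond the scatter) in this assay. This shows that the position is sensitive to which of the two halogens it carries, since the step is modest but lies beyond the usual scatter of the read-out, and the direction is toward weaker inhibition with fluoro in place. Nothing measured here explains why the two halogens differ at this carbon.

This single pair gives only two points at this position, so it leaves open how a hydrogen, a chloro, a methyl or a methoxy group on the same carbon would compare with bromo and fluoro, and whether a larger group such as a phenyl ring would be accepted there. It also leaves open whether the same exchange of bromo for fluoro would give a step of similar size at another aromatic carbon of the shared core.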